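Phenyl on the ring carbon of compound 3

This account rests on a few compounds, and the source may have more. Where it says the series, first, only, none or still open, it means among the compounds named here.

Working notes on a small set of sulfonamides sharing one core, all tested in a functional assay on A2780 cells (Homo sapiens) for antiproliferative activity, read by sulforhodamine B assay, with a stated time of 48 h; on this read-out lower numbers stand for stronger inhibition of growth and higher numbers for weaker inhibition of growth. Compound 1 `Cc1ccc(S(=O)(=O)N2CCC(Cl)CC2)cc1` gives only a limit in this assay, > 100000 nM. Compound 3 `Cc1ccc(S(=O)(=O)N2CC=C(Cl)CC2)cc1` likewise returns only a limit, > 100000 nM. For the measured compounds named here, compound 2 `Cc1ccc(S(=O)(=O)N2CC[C@@H](Cl)C[C@@H]2CC(C)C)cc1` is the single member with a number, giving 36000 nM in this assay. Going by the values given here, the one measured step, an at least 2.7-fold lower number from compound 1 to compound 2 (0.44 log units; beyond the scatter), is known only as a lower bound because of the limit of > 100000 nM in this assay, at which 2 of the 3 values shown sit.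

Compound 4 `Cc1ccc(S(=O)(=O)N2CCC(Cl)=CC2c2ccccc2)cc1` is not yet measured. It differs from compound 3 by phenyl in place of hydrogen on a saturated ring carbon. Among the compounds with values here, the only step that bears on this change is the isobutyl step on the same kind of saturated ring carbon, which was at least modest and downward. A carbon-only group entering at a saturated ring carbon of compound 3 is therefore expected to give a step of comparable size and direction, an at least 2.8-fold lower number from compound 3 to compound 4 (0.45 log units; beyond the scatter), although the limit on compound 3 leaves its starting point open. Compound 4 is estimated at 35000 nM in this assay, with a range from 12000 nM to 110000 nM.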

Compound 4, concentration for 50% growth inhibition: 17000 nM
For compound 4 the middle estimate is 2.1-fold (0.31 log units) above the measured one; the range from low to high includes it.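

In this assay, phenyl on the saturated ring carbon next to the ring nitrogen gives an at least 5.8-fold lower number from compound 3 to compound 4 (0.76 log units; beyond the scatter), so the core of compound 3 can also yield a measurable number. Previously, only the isobutyl step on the core of compound 1 had shown a downward move; a carbon-only group at such a ring carbon now lowers the number in two pairs, one on each core. Going by these compounds, the full size of the new step remains unknown, and it can be read only as a lower bound because of the assay limit: the limit of > 100000 nM in this assay, at which 2 of the 4 values shown sit.

An amine, a carboxylic acid or a longer chain at this ring carbon would test whether the lowering is confined to carbon-only groups. For the compounds shown here, whether phenyl and isobutyl differ on a single core also remains open, as each appears here on only one core.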